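This account rests on a few compounds, and the source may have more. Where it says the series, first, only, none or still open, it means among the compounds named here.

Measured so far in a functional assay on KYSE-70 cells for antiproliferative activity against KYSE-70 cell line (Homo sapiens), read by MTT assay, with a stated time of 72 h; on this read-out higher numbers stand for weaker inhibition and lower numbers for stronger inhibition:
compound 1 `C#CCSc1nc(Sc2ccccn2)c(C#N)c(-c2cc(OC)c(OC)c(OC)c2)n1` gives > 10000 nM (a limit of the assay, not a number)
compound 2 `C#CCSc1nc(Sc2nccs2)c(C#N)c(-c2ccc(Cl)cc2)n1` gives 5350 nM

Compound 1 stands at the limit of > 10000 nM in this assay, at which 1 of the 2 values shown sits, so it has no measured potency to build on. Compound 3 `C#CCSc1nc(Sc2nc(C)cs2)c(C#N)c(-c2cc(OC)c(OC)c(OC)c2)n1` carries 4-methyl-1,3-thiazol-2-yl in place of pyridin-2-yl on a sulfur, with the rest of compound 1 unchanged. The counted change is 4-methyl-1,3-thiazol-2-yl in place of pyridin-2-yl on a sulfur.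

Within the data shown here, no measured step bears on this change, so the expectation is a weak one. Among the measured compounds shown here, the only number available is that of compound 2 at 5350 nM, and it shows that measurable inhibition occurs. Expected here is an at least 1.4-fold lower number from compound 1 to compound 3 (0.15 log units; that floor lies within the scatter), a small move toward stronger inhibition. Compound 3 is estimated at 7000 nM, with an expected range from 2500 nM to 10000 nM, and a result reported only as a limit would not be surprising.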

Compound 3, half-maximal inhibitory concentration: > 20000 nM
Compound 3: only a limit was reported; the forecaster's own chance of this, stated with the estimate: 40%; middle value at least 2.8-fold (0.45 log units) away from the limit.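

In this assay, compound 1 and compound 3 are both reported only as limits, so no step can be read for 4-methyl-1,3-thiazol-2-yl in place of pyridin-2-yl on a sulfur. The compounds shown leave open whether this change shifts inhibition at all, and in which direction.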